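The source may hold more compounds than are shown below. What is called first, only, known or untested is meant among the compounds shown, and "the series" means these compounds.

Working notes on a small set built on one shared core. Compound 1 `Oc1ccc(-c2cc(-c3cccnc3)nc(-c3ccccc3Cl)c2)cc1` carries a pyridin-3-yl group, a 2-chlorophenyl group and a 4-hydroxyphenyl group, and in an assay on isolated protein for inhibition of DNA topoisomerase 1 (Homo sapiens), with a stated time of 30 min, tested at 100 uM (a higher number here means a stronger effect of the compound at the concentration tested, a lower number a weaker effect), compound 1 gives 0.9% at the single test concentration. Compound 2 `Oc1cccc(-c2cc(-c3ccsc3)nc(-c3cccc(Cl)c3)c2)c1` gives 26.2% in this assay and compound 3 `Oc1ccc(-c2cc(-c3cccnc3)nc(-c3cccc(Cl)c3)c2)cc1` gives 55.2% there. Compound 1 thus stands lowest of the three numbers, with compound 2 as its nearest neighbour and compound 3 as the furthest, both beyond the scatter. Among the compounds with values here, the only step between two compounds differing in one place is a number 54.3 percentage points higher from compound 1 to compound 3 (beyond the scatter) and it concerns the chlorophenyl group alone. Compound 2 and compound 3 differ in two places at once, so their values are simply set side by side.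

Compound 4 `Oc1ccc(-c2cc(-c3ccccn3)nc(-c3ccccc3Cl)c2)cc1` is the next member. Against compound 1 the change is pyridin-2-yl in place of pyridin-3-yl on an aromatic carbon while the 2-chlorophenyl group is kept. Within the data shown here, no measured step touches the pyridyl group, and the one step known exchanges 3-chlorophenyl for 2-chlorophenyl, which compound 4 does not do. There is therefore no ground for expecting a step beyond the scatter in this assay in either direction. The estimate for compound 4 is 6% with a range from 0% to 25% in this assay. The step this expectation implies is a number 5.1 percentage points higher from compound 1 to compound 4 (within the scatter) and is expected to stay within the scatter.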

Compound 4, a percentage reported as inhibition, at one concentration (the size of the read-out at that concentration, not a potency): 5.2%
Estimate against measurement, compound 4: 0.8 percentage points above, and the stated range covers the measured number.
By their numbers in this assay, from the lowest: compounds 1 and 4 (each within the scatter of the next); then compound 2; then compound 3.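

The pyridyl position now has a step of its own: in this assay pyridin-2-yl in place of pyridin-3-yl, with the 2-chlorophenyl group kept, gives a number 4.3 percentage points higher from compound 1 to compound 4 (within the scatter) and so moving the ring nitrogen to this place makes no readable difference on this background. Within the data shown here, the two groups have the same atoms and the same counts of hydrogen-bond donors and acceptors, whereas the exchange of the chlorophenyl group gives a number 54.3 percentage points higher from compound 1 to compound 3 (beyond the scatter) and remains the only single-place change here that goes beyond the scatter. Nothing measured on hand offers an explanation for this result.

As far as these compounds go, the reading holds only with the 2-chlorophenyl group in place, where both numbers are low, so it remains open whether the same pyridyl exchange would stay within the scatter alongside the 3-chlorophenyl group of compound 3. Also open, from the compounds shown here alone, is how this position would respond to a pyridin-4-yl group, or to an aromatic ring carrying an amine or a carboxylic acid.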